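Dichlorophenyl in place of methoxyphenyl on the shared core

The source may hold more compounds than are shown below. What is called first, only, known or untested is meant among the compounds shown, and "the series" means these compounds.

Compound 1 `CC(C)(C)c1ccc(OCCCON2C(N)=NC(N)=NC23CCSCC3)cc1` was examined in an assay on isolated protein for inhibition of Dihydrofolate reductase (Homo sapiens), read by spectrophotometry, using NADPH, with stated times of 5 s and 6 min, tested at 50 uM (on this read-out lower numbers stand for a weaker effect and higher numbers for a stronger effect at the one concentration tested), and compound 1 gives 86.6%. Compound 2 `COc1ccc(OCCCON2C(N)=NC(N)=NC23CCOCC3)cc1` has no number in this assay; the entry of compound 2 reads "not determined" (no result reported). The entry of compound 3 `NC1=NC2(CCSCC2)N(OCCCOc2ccc(Br)cc2)C(N)=N1` in this assay reads "not determined" (no result reported), so compound 2 stands without a measured value. Compound 4 `NC1=NC2(CCOCC2)N(OCCCOc2cccc(Cl)c2Cl)C(N)=N1` has not yet been tested. It differs from compound 2 by 2,3-dichlorophenyl in place of 4-methoxyphenyl on an oxygen on a saturated carbon. Going by the values given here, with no measured number for compound 2, the size of the step cannot be computed; what is known is only that compound 1 reaches a high inhibition in this assay. Compound 4 is expected to give about 75% in this assay, estimated within a range from 45% to 95%.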

Compound 4, a percentage reported as inhibition, at one concentration (the size of the read-out at that concentration, not a potency): 89.8%
Estimate against measurement, compound 4: 14.8 percentage points below; measured number inside the range.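

No step can be read between compound 2 and compound 4. The compounds shown leave open what 2,3-dichlorophenyl in place of 4-methoxyphenyl does to the inhibition on the shared core. No supporting evidence bears on this result.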